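Swapping the amino group of a growth inhibitor for fluoro

The source may report more compounds than this note shows. Statements on the series, on what has been measured and on what is new or still open speak of the compounds shown alone.

Measured in a functional assay on A549 cells (Homo sapiens) for antiproliferative activity, read by sulforhodamine B assay, with a stated time of 48 h; on this read-out lower numbers stand for stronger inhibition of growth and higher numbers for weaker inhibition of growth:
- compound 1 `N#Cc1ccc(Nc2nc(NCCCO)c3ccccc3n2)cc1` gives 3000 nM
- compound 2 `Nc1ccc(Nc2nc(NCCCO)c3ccccc3n2)cc1` gives 17100 nM

Of these two compounds, compound 2 has the higher number at 17100 nM, so it inhibits growth less strongly in this assay. Among the measured compounds shown here, only one measured step bears on what comes next: a 5.7-fold higher number from compound 1 to compound 2 (0.76 log units; beyond the scatter). That step put amino in place of cyano on an aromatic carbon.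

Compound 3 `OCCCNc1nc(Nc2ccc(F)cc2)nc2ccccc12` changes that same carbon again, with fluoro in place of amino on an aromatic carbon. Fluoro has not yet been measured on this core, so the single step is only a rough guide. Going by a 5.7-fold higher number from compound 1 to compound 2 (0.76 log units; beyond the scatter), losing the amino group is expected to lower the number modestly, by no more than that step. The expected change is a 2.4-fold lower number from compound 2 to compound 3 (0.39 log units; beyond the scatter). For compound 3 the estimated value is 7000 nM, with an expected range from 2500 nM to 20000 nM.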

Compound 3, concentration for 50% growth inhibition: 19300 nM
Estimate against measurement, compound 3: 2.8-fold (0.44 log units) below, within the range that was stated.
By their numbers in this assay, from the lowest: compound 1; then compounds 2 and 3 (each within the scatter of the next).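

Fluoro in place of amino on this carbon, para to a large group, gives a 1.1-fold higher number from compound 2 to compound 3 (0.05 log units; within the scatter) in this assay, so the two groups cannot be told apart here. The group leaving carries a hydrogen-bond donor and acceptor and the group entering carries neither, yet that difference in the count leaves no readable mark on this read-out. Fluoro in place of cyano gives a 6.4-fold higher number from compound 1 to compound 3 (0.81 log units; beyond the scatter), so among the three groups shown, cyano alone stands apart from the others, and no measurement at hand says why.

A methoxy group or a carboxylic acid on the same carbon could fall with cyano or with the other two, and the compounds shown do not tell which. From the compounds shown here alone, whether the gap between cyano and the other groups persists with a longer chain in place of the hydroxyl-bearing one also stays open.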